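This account rests on a few compounds, and the source may have more. Where it says the series, first, only, none or still open, it means among the compounds named here.

In a functional assay on A549 cells (Homo sapiens) for antiproliferative activity, read by MTT assay, with a stated time of 72 h (on this read-out higher numbers stand for weaker inhibition and lower numbers for stronger inhibition), compound 2 `CC/C=C\C(=O)Nc1cc(Nc2ncc(C#N)c(-c3cn(C)c4ccccc34)n2)c(OC)cc1N(C)CCN(C)C` gives 162 nM, the lowest of the two numbers recorded so far, while compound 1 `COc1cc(N(C)CCN(C)C)c(NC(=O)/C=C\C(C)C)cc1Nc1nccc(-c2cn(C)c3ccccc23)n1` gives 612 nM, a gap beyond the usual scatter. Compound 3 `COc1cc(N(C)CCN(C)C)c(NC(=O)/C=C\C(C)C)cc1Nc1ncc(C#N)c(-c2cn(C)c3ccccc23)n1` differs from compound 2 by methyl in place of hydrogen on a saturated chain carbon bound to a double-bonded chain carbon and a saturated chain carbon. Among the measured compounds shown here, no pair of measured compounds isolates this single change, so its direction is uncertain. The step from compound 2 to compound 3 in this assay is expected to be small, within the scatter, as a 1.2-fold higher number from compound 2 to compound 3 (0.09 log units; within the scatter). For compound 3 the estimated value is 200 nM, expected to fall between 80 nM and 500 nM.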

Compound 3, half-maximal inhibitory concentration: 1100 nM
Compound 3: middle estimate off by 5.5-fold (0.74 log units), on the low side; the whole stated range lies below it.
By their numbers in this assay, from the lowest: compound 2; then compounds 1 and 3 (each within the scatter of the next).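

Going from ethyl to isopropyl, a single added methyl on this saturated chain carbon, gives a 6.8-fold higher number from compound 2 to compound 3 (0.83 log units; beyond the scatter) in this assay and so costs clear activity, showing that this carbon tolerates even one extra carbon poorly. With isopropyl in place, cyano in place of hydrogen on an aromatic carbon gives a 1.8-fold higher number from compound 1 to compound 3 (0.25 log units; within the scatter) in this assay and so has no readable effect in this pair. No measurement here accounts for the methyl step.

From the compounds shown here alone, how a longer chain such as propyl or an amine such as dimethylamino would behave on this carbon remains open. So does whether the methyl step would be the same size without the nitrile.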